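Notes on an aryl swap in a small series

The compounds below may be only part of what the source reports. "The series", "measured", "known", "first", "only" and "open" are said of these compounds alone.

Measured in a functional assay on NCI/ADR cells (Homo sapiens) for cytotoxicity, read by sulforhodamine B assay; a higher number here means a weaker inhibitor of growth, a lower number a stronger inhibitor of growth:
- compound 1 `CC1=CC[C@@H]([C@@](C)(O)CCCC(C)(C)NC(=S)NN)CC1`: 29000 nM
- compound 2 `CC1=CC[C@@H]([C@@](C)(O)CCCC(C)(C)NC(=S)N/N=C\c2ccc(O)cc2)CC1`: 6070 nM

Compound 2 has the lower number of the two. Compound 3 `CC1=CC[C@@H]([C@@](C)(O)CCCC(C)(C)NC(=S)N/N=C\c2cccc(Cl)c2)CC1` is unmeasured and has 3-chlorophenyl in place of 4-hydroxyphenyl on a carbon with a double bond to nitrogen. Going by the values given here, the only measured step is a 4.8-fold lower number from compound 1 to compound 2 (0.68 log units; beyond the scatter). That step added the whole aromatic group, so it bears only loosely on a swap of one aromatic group for another. Among the compounds with values here, no measured step tests such a swap, so no change beyond the scatter is expected in this assay. For compound 3 the expected change is a 1.2-fold lower number from compound 2 to compound 3 (0.08 log units; within the scatter). Compound 3 is estimated at 5000 nM, with an expected range of 2000 nM to 13000 nM.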

Compound 3, concentration for total growth inhibition: 31900 nM
Compound 3: the middle estimate sits 6.4-fold (0.80 log units) below what was measured; measured number above the stated range.
By their numbers in this assay, from the lowest: compound 2; then compounds 1 and 3 (each within the scatter of the next).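

The aromatic group on the carbon with a double bond to nitrogen matters in this assay since a 5.3-fold higher number from compound 2 to compound 3 (0.72 log units; beyond the scatter) separates 3-chlorophenyl from 4-hydroxyphenyl at this place. The gain seen with compound 2 does not extend to every aromatic group, and a 1.1-fold higher number from compound 1 to compound 3 (0.04 log units; within the scatter) leaves compound 3 within the scatter of the compound without one. No measurement at hand accounts for the difference between these two groups.

Open, going by these compounds, is whether the shift follows the loss of the hydroxyl, the arrival of the chlorine, or the changed ring position. A 4-chlorophenyl or 3-hydroxyphenyl group would separate these.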